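The compounds below may be only part of what the source reports. "The series", "measured", "known", "first", "only" and "open" are said of these compounds alone.

Measured so far in an ADME assay on microsomes from liver (Mus musculus) for metabolic stability, read by LC-MS, with a stated time of 40 min, tested at 0.5 uM; a lower number here means slower removal, a higher number faster removal of the compound:
- compound 1 `O=C(Nc1cccc(S(=O)(=O)C2CCCC2)c1)c1cccnc1N1CCC(F)(F)CC1`: > 399 mL.min-1.g-1 (a limit of the assay, not a number)
- compound 2 `CC(C)(C)NS(=O)(=O)c1cccc(NC(=O)c2ccc(NS(=O)(=O)C3(C)CC3)cc2N2CCC3(CC2)CC3)c1`: 90 mL.min-1.g-1

In this assay, going by the values given here, compound 2 stands at 90 mL.min-1.g-1, the only exact number available. The reading for compound 1 is only a limit. Among the compounds with values here, no measured step exists yet, so any expectation for a change has no direct support from the data.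

The next compound to be measured is compound 3 `CC(C)(C)NS(=O)(=O)c1cccc(NC(=O)c2ccc(NS(C)(=O)=O)cc2N2CCC3(CC2)CC3)c1`, which carries methyl in place of 1-methylcyclopropyl on a sulfonyl sulfur, and the rest of the structure matches compound 2. The counted difference is methyl in place of 1-methylcyclopropyl on a sulfonyl sulfur.

A modest shift towards slower removal is expected, of a size probably not beyond the usual scatter, starting from compound 2 at 90 mL.min-1.g-1. The expected change is a 1.5-fold lower number from compound 2 to compound 3 (0.18 log units; within the scatter). The estimate for compound 3 is 60 mL.min-1.g-1. The expected range for compound 3 runs from 25 mL.min-1.g-1 to 140 mL.min-1.g-1.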

Compound 3, intrinsic clearance in microsomes: 81 mL.min-1.g-1
Estimate against measurement, compound 3: 1.4-fold (0.13 log units) below; measured number inside the range.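

In this assay, the sulfonyl sulfur now has its first measured step, and methyl in place of 1-methylcyclopropyl gives a 1.1-fold lower number from compound 2 to compound 3 (0.05 log units; within the scatter). On this pair, losing the three-membered ring of carbon on a sulfonyl sulfur whose other neighbour is the sulfonamide nitrogen does not move the read-out beyond the scatter, so compound 2 and compound 3 read as equivalent in this assay. Nothing in the data shown bears on why this step is so small.

As far as these compounds go, only 1-methylcyclopropyl and methyl have values at this place, so it remains open whether a group of another kind there, such as a hydroxyethyl chain, an amine or a carboxylic acid, would shift the number beyond the scatter, and whether the other parts of the shared core matter more for removal in this assay. Going by these compounds alone, compound 1 reads > 399 mL.min-1.g-1, which is a limit of the assay and not a number, and it differs from compound 2 and compound 3 in more than one place, so it adds no step.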